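Cyano for Methoxy on the Benzyl Arm of Chromone Amides

A few compounds are considered here, and "the series" means these few. Any claim that something is new, unique, unknown or untested is made for them only; others in the source may bear on it.

Three compounds were tested in a functional assay on HepG2 cells (Homo sapiens) for cytotoxicity, read by MTT assay, with a stated time of 72 h; on this read-out higher numbers stand for weaker inhibition and lower numbers for stronger inhibition. Compound 1 `N#Cc1ccc(CN2CCC(NC(=O)COc3ccc4c(=O)c(-c5ccccc5)coc4c3)CC2)cc1` carries a cyanobenzyl group on the piperidine; in this assay compound 1 gives > 20000 nM, which is a limit of the assay and not a number. Compound 2 `COc1ccc(CN2CCC(NC(=O)COc3ccc4c(=O)c(-c5ccccc5)coc4c3)CC2)cc1` bears a methoxybenzyl group on the same core; compound 2 also gives > 20000 nM, again a limit rather than a number. The change between them is cyano in place of methoxy on an aromatic carbon, and the step that the two limits leave unreadable from compound 2 to compound 1 cannot be read because the limit of > 20000 nM in this assay, at which 2 of the 3 values shown sit, covers both ends of it.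

Compound 3 `COc1ccc(CN2CCC(NC(=O)COc3ccc(-c4cc(=O)c5ccccc5o4)cc3)CC2)cc1` has a different core; the difference between the core of compound 3 and that of compound 2 is not broken down here. Within the data shown here, compound 3 gives 6800 nM in this assay, the only numerical reading among the three.

Going by these compounds, compound 4 `N#Cc1ccc(CN2CCC(NC(=O)COc3ccc(-c4cc(=O)c5ccccc5o4)cc3)CC2)cc1` is untested. It differs from compound 3 by cyano in place of methoxy on an aromatic carbon, the same kind of change as that from compound 2 to compound 1, made on the core of compound 3. Since the measured instance of this change sits entirely at the limit, it gives no size to carry over. The step from compound 3 to compound 4 is therefore expected to be small, a 1.2-fold higher number from compound 3 to compound 4 (0.07 log units; within the scatter), resting on the value of compound 3 6800 nM as the anchor. Compound 4 is estimated at 8000 nM, with a likely range from 3000 nM to 20000 nM.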

Compound 4, half-maximal inhibitory concentration: 6700 nM
Compound 4: middle estimate off by 1.2-fold (0.08 log units), on the high side; the range from low to high includes it.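

In this assay, cyano in place of methoxy on the core of compound 3 gives a 1.0-fold lower number from compound 3 to compound 4 (0.01 log units; within the scatter), so on this core the exchange of 4-methoxybenzyl for 4-cyanobenzyl shifts the reading by no more than repeated measurements would. This single pair shows what the change does on one core only, and it does not show that the change would be equally silent on the core of compound 1 or that the two cores respond alike. The same change from compound 2 to compound 1 cannot be read, which leaves no measured size to set beside the new step and no comparison of the change across the two cores: the limit of > 20000 nM in this assay, at which 2 of the 4 values shown sit.

The compounds shown leave open whether any other group in this place, para to a large group, such as an amine, a carboxylic acid or a trifluoromethyl group, would move the reading on the core of compound 3, where a number can be read. They also leave open whether a longer chain in place of the benzyl arm would give a reading different from those of compound 3 and compound 4.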